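The source may report more compounds than this note shows. Statements on the series, on what has been measured and on what is new or still open speak of the compounds shown alone.

Series notes, this assay

All three measured compounds were run in a functional assay on VCaP cells (Homo sapiens) for antiproliferative activity, read by propidium iodide staining, with a stated time of 96 h; a lower number here means a stronger inhibitor, a higher number a weaker inhibitor:

compound 1, `CC(O)(CSc1cccc(C(F)(F)F)c1)C(=O)Nc1cccc(S(F)(F)(F)(F)F)c1`, gives 20200 nM
compound 2, `CC(O)(CSc1cccc(OC(F)(F)F)c1)C(=O)Nc1cccc(S(F)(F)(F)(F)F)c1`, gives 17500 nM
compound 3, `CC(O)(COc1ccccc1C(F)(F)F)C(=O)Nc1cccc(S(F)(F)(F)(F)F)c1`, gives 36700 nM

Compound 1 and compound 2 share a core and differ in one place: trifluoromethoxy in place of trifluoromethyl on an aromatic carbon. That change produced a 1.2-fold lower number from compound 1 to compound 2 (0.06 log units; within the scatter), so the two values cannot be told apart.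

Compound 3 stands on a different core; the difference between the core of compound 3 and the core of compound 1 is not broken down here. Compound 3 has the highest number of the three, but its gap to compound 1 lies within the scatter, and only its gap to compound 2 lies beyond it, so no ordering against compound 1 is claimed.

Compound 4, `CC(O)(COc1ccccc1OC(F)(F)F)C(=O)Nc1cccc(S(F)(F)(F)(F)F)c1`, is not yet measured. It differs from compound 3 by trifluoromethoxy in place of trifluoromethyl on an aromatic carbon. For the measured compounds named here, this is the same kind of change as the one from compound 1 to compound 2, not the same change: there the place is meta to a large group, here it is ortho to a large group.

On that one earlier instance, the step from compound 3 to compound 4 is expected to be about a 1.2-fold lower number from compound 3 to compound 4 (0.07 log units; within the scatter), beside the earlier 1.2-fold lower number from compound 1 to compound 2 (0.06 log units; within the scatter). Going by the values given here, the expectation rests on compound 3 at 36700 nM and on the single earlier step, which was within the scatter. Compound 4 is estimated at 31000 nM. The estimate for compound 4 is expected to lie between 14000 nM and 65000 nM.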

Compound 4, half-maximal inhibitory concentration: 27700 nM
Beside the measured number, compound 4's estimate is 1.1-fold (0.05 log units) above it, and the stated range covers the measured number.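

In this assay, trifluoromethoxy in place of trifluoromethyl gives a 1.3-fold lower number from compound 3 to compound 4 (0.12 log units; within the scatter), and this step can be set against the earlier one: the same change on two cores in this assay, a 1.2-fold lower number (0.06 log units; within the scatter) from compound 1 to compound 2 and a 1.3-fold lower number (0.12 log units; within the scatter) from compound 3 to compound 4, 1.1-fold (0.06 log units) apart, within the scatter of two such steps. The change therefore carries from the core of compound 1 to the core of compound 3 without a detectable difference in step size, although on each core the two compounds of the pair cannot be told apart. This does not show that the change lowers the number on either core, since two steps within the scatter fit equally well with no effect at all, and two cores give no basis for predicting the step on a third.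

The compounds shown leave open whether a group other than these two fluorinated ones, such as a nitrile, an amine or a carboxylic acid on the same aromatic carbon, would give a step beyond the scatter. They also leave open how the number responds to changes elsewhere in the molecule, since the tertiary alcohol, the amide and the pentafluorosulfanyl group are the same in all four compounds.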